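The source may hold more compounds than are shown below. What is called first, only, known or untested is meant among the compounds shown, and "the series" means these compounds.

Compound 1 `NS(=O)(=O)CC(=O)NCCSc1nonc1/C(=N/O)Nc1ccc(F)c(C(F)F)c1`: in an ADME assay on isolated protein for pharmacokinetics, with UDP-glucuronosyltransferase 1A9 (Homo sapiens) as the target, read by LC-MS, with a stated time of 60 min, at 37 degrees C, tested at 1 uM, in the presence of a further agent that is not named here (on this read-out higher numbers stand for a longer-lived compound and lower numbers for a shorter-lived compound), compound 1 gives > 3 h, which is a limit of the assay rather than a number.
Compound 2 `C[C@H](CSc1nonc1/C(=N/O)Nc1ccc(F)c(Br)c1)NC(=O)CS(N)(=O)=O`: in this assay compound 2 gives 1.33 h.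
Compound 3 `NS(=O)(=O)CC(=O)NCCSc1nonc1/C(=N/O)Nc1ccc(F)c(Br)c1`: in this assay compound 3 gives 0.758 h.

Of the two numbers recorded, compound 3 holds the lowest, with compound 2 nearest to it; the gap between these two lies within the scatter, so no order can be read between them. The third measured compound sits at a limit, (the limit of > 3 h in this assay, at which 1 of the 3 values shown sits), and the step from it is known only as a bound: an at least 3.9-fold lower number from compound 1 to compound 3 (0.59 log units; beyond the scatter).

Compound 4 `C[C@@H](CSc1nonc1/C(=N/O)Nc1ccc(F)c(Br)c1)NC(=O)CS(N)(=O)=O` differs from compound 3 in a single place: methyl in place of hydrogen on a saturated chain carbon bound to an amide-type nitrogen and a saturated chain carbon. For the measured compounds named here, one measured step bears directly on this change, in the opposite direction: a 1.8-fold lower number from compound 2 to compound 3 (0.24 log units; within the scatter), a step that stayed within the scatter. Read backwards, it points to a small rise for compound 4, of a size that would not count as a real change.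

Compound 4 is therefore expected to give about 1.2 h in this assay, with a range from 0.6 h to 2.4 h. The expected step of a 1.6-fold higher number from compound 3 to compound 4 (0.20 log units; within the scatter) is estimated to remain within the scatter.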

Compound 4, half-life: > 3 h
Compound 4 gave a limit, no number; the forecaster's own chance of this, stated with the estimate: 5%; at least 2.5-fold (0.39 log units) between middle value and limit.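

Methyl in place of hydrogen on this saturated chain carbon turns out to be a real change in this assay when the stereocentre is drawn as in compound 4: the step of an at least 3.9-fold higher number from compound 3 to compound 4 (0.59 log units; beyond the scatter) is one that the earlier pair, compound 2 and compound 3, did not show, since their step stayed within the scatter. The configuration at that carbon, not the presence of the methyl alone, therefore sets the outcome, and the step of an at least 2.2-fold higher number from compound 2 to compound 4 (0.35 log units; beyond the scatter) can be laid on that stereocentre alone because of one point: the fact that compounds 2 and 4 differ only in the configuration as drawn. Compound 4 gives > 3 h as a limit of the assay and not as a number, so both new steps are bounds only, and this limit is shared: the limit of > 3 h in this assay, at which 2 of the 4 values shown sit.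

From the compounds shown here alone, how far compound 4 lies past that limit stays open, and with it the true size of the gap between the two configurations. Going by these compounds, it is also open whether an ethyl or a hydroxymethyl group on the same saturated chain carbon, drawn S, would keep the longer half-life seen with methyl.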